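The source may hold more compounds than are shown below. What is called first, only, known or untested is meant among the compounds shown, and "the series" means these compounds.

Measured so far:
compound 1, `CCOc1ccc(NC2=CC(=O)c3c(nc4n3[C@H]3OC[C@@H](O)[C@H]3OC4)C2=O)cc1`, 2090 nM
compound 2, `Cc1ccc(NC2=CC(=O)c3c(nc4n3[C@H]3OC[C@@H](O)[C@H]3OC4)C2=O)cc1`, 1550 nM
compound 3, `O=C1C(Nc2ccc(C(F)(F)F)cc2)=CC(=O)c2c1nc1n2[C@H]2OC[C@@H](O)[C@H]2OC1`, 1860 nM

All three share a core and differ only in the group on the aromatic ring of the arylamine. In a functional assay on MGC-803 cells (Homo sapiens) for inhibition, read by sulforhodamine B assay (on this read-out higher numbers stand for weaker inhibition and lower numbers for stronger inhibition), compound 2 stands at the low end of the three numbers, but the step of a 1.3-fold lower number from compound 1 to compound 2 (0.13 log units; within the scatter) and the step of a 1.2-fold higher number from compound 2 to compound 3 (0.08 log units; within the scatter) are both within the scatter, as is a 1.1-fold lower number from compound 1 to compound 3 (0.05 log units; within the scatter), so the three compounds cannot be told apart on these data.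

Compound 4, `O=C1C(N2CCC2)=CC(=O)c2c1nc1n2[C@H]2OC[C@@H](O)[C@H]2OC1`, differs from compound 2 in one place: azetidin-1-yl in place of (4-methylphenyl)amino on a double-bonded ring carbon. This is a different kind of change from the three measured steps, each of which only exchanged a group on the aromatic ring and left the arylamine itself in place. None of those steps moved the number beyond the scatter, and none bears directly on removing the aromatic ring and the donor. The expectation for compound 4 therefore rests on compound 2 alone, with a wide range, and the estimated step is a 2.3-fold higher number from compound 2 to compound 4 (0.35 log units; beyond the scatter). Compound 4 is expected to give about 3500 nM in this assay, between 800 nM and 15000 nM.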

Compound 4, half-maximal inhibitory concentration: > 16000 nM
Compound 4: a limit, no number (the forecaster's own chance of this, stated with the estimate: 10%); middle value at least 4.5-fold (0.66 log units) from the limit.
By their numbers in this assay, from the lowest: compounds 2, 3 and 1 (each within the scatter of the next). At a limit, above all of these: compound 4.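

Compound 4 reads only as a limit of the assay and not as a number: the limit of > 16000 nM in this assay, at which 1 of the 4 values shown sits.

Even so, in this assay, azetidin-1-yl in place of (4-methylphenyl)amino on the double-bonded ring carbon gives an at least 10-fold higher number from compound 2 to compound 4 (1.01 log units; beyond the scatter), the only step shown that lies beyond the scatter, whereas the three arylamines all stay within the scatter of one another. Among the compounds shown, the number at this position therefore depends far more on replacing the whole arylamine than on whether its aromatic ring carries ethoxy, methyl or trifluoromethyl.

This single change removes the aromatic ring and the amine hydrogen together and also brings in a four-membered ring, so the compounds shown cannot separate these features. From the compounds shown here alone, it remains open whether cyclohexylamino, which keeps the amine hydrogen without the aromatic ring, or (methyl)(4-methylphenyl)amino, which keeps the aromatic ring without that hydrogen, would stay within the scatter of the arylamines or would also move the number beyond it.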